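Vinyl to ethynyl on two fused heteroaromatic cores

The compounds below may be only part of what the source reports. "The series", "measured", "known", "first", "only" and "open" are said of these compounds alone.

Measured compounds, all in a functional assay on HCT-116 cells (Homo sapiens) for cytotoxicity, with a stated time of 3 days; on this read-out lower numbers stand for stronger inhibition and higher numbers for weaker inhibition:
compound 1 `C=Cc1nc2ccccc2[se]1`: > 40000 nM, a limit of this assay and not a number.
compound 2 `C#Cc1nc2ccccc2[se]1`: 25000 nM.
compound 3 `C=Cc1nc2ccccc2o1`: > 40000 nM, again a limit and not a number.

Going by the values given here, the only measured step is an at least 1.6-fold lower number from compound 1 to compound 2 (0.20 log units; that floor lies within the scatter), the change being (ethynyl in place of vinyl on an aromatic carbon). Its size rests on (the limit of > 40000 nM in this assay, at which 2 of the 3 values shown sit), so the step is itself only a floor. Compound 4 `C#Cc1nc2ccccc2o1` is not yet measured in this assay; it stands to compound 3 by ethynyl in place of vinyl on an aromatic carbon. This is the same kind of change as before, not the same: around the place the five-membered aromatic ring holds oxygen in compound 3 and compound 4 where it holds selenium in compound 1 and compound 2. The difference between the two cores is not broken down here. From compound 3 to compound 4 a step of about the earlier size is expected, a number no higher from compound 3 to compound 4 (the limit leaves the size open), because an at least 1.6-fold lower number from compound 1 to compound 2 (0.20 log units; that floor lies within the scatter) reached only a floor within the scatter. The estimate for compound 4 is 40000 nM, expected between 15000 nM and 100000 nM.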

Compound 4, half-maximal inhibitory concentration: 11600 nM
Compound 4: middle estimate off by 3.4-fold (0.54 log units), on the high side, outside the stated range (below it).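

On the core of compound 3, ethynyl in place of vinyl on an aromatic carbon gives, in this assay, an at least 3.4-fold lower number from compound 3 to compound 4 (0.53 log units; beyond the scatter), so on this core the change stands clear of the scatter. On the core of compound 1 the change points the same way, but no difference in its size between the two cores can be claimed: the same change on two cores in this assay, an at least 1.6-fold lower number (0.20 log units; that floor lies within the scatter) from compound 1 to compound 2 and an at least 3.4-fold lower number (0.53 log units; beyond the scatter) from compound 3 to compound 4; the limit leaves it open whether they differ. From the compounds shown here alone, compound 1 and compound 3 are both limits and not numbers, so each step is only a floor and its full size on either core stays unknown: the limit of > 40000 nM in this assay, at which 2 of the 4 values shown sit.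

The compounds shown carry only vinyl or ethynyl on this aromatic carbon. Going by these compounds, whether a nitrile, an amine or a longer alkyne chain at the same place would give a lower number in this assay remains open.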